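The source may report more compounds than this note shows. Statements on the series, on what has been measured and on what is new or still open speak of the compounds shown alone.

All four compounds share the same large oxygen-rich ring, differing only in the acid part of the ester attached to it. Compound 1 `CC(C)=CC1C(C(=O)OCC2COCCOCCOCCOCCOCCO2)C1(C)C` carries a 2,2-dimethyl-3-(2-methylprop-1-en-1-yl)cyclopropyl group on the carbonyl carbon. In a functional assay on HeLa cells (Homo sapiens) for inhibition, read by sulforhodamine B assay, with a stated time of 48 h (a higher number here means a weaker inhibitor of growth, a lower number a stronger inhibitor of growth), compound 1 gives 63000 nM. Compound 2 `O=C(CCCCCCCCCCOc1ccccc1)OCC1COCCOCCOCCOCCOCCO1` bears a long chain ending in a phenoxy group, and in this assay compound 2 gives 41000 nM; this number is within the usual scatter of the value of compound 1, so the two cannot be told apart. Compound 3 `O=C(CCCc1cc2ccccc2[nH]1)OCC1COCCOCCOCCOCCOCCO1` carries an indole-bearing chain, and in this assay compound 3 reaches only a limit of the assay, > 100000 nM. Of the two numbers, compound 1 has the higher one, with compound 2 close by.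

Compound 4 `O=C(OCC1COCCOCCOCCOCCOCCO1)c1cccnc1` is the untested member. It differs from compound 1 in one place: pyridin-3-yl in place of 2,2-dimethyl-3-(2-methylprop-1-en-1-yl)cyclopropyl on a carbonyl carbon. Within the data shown here, no measured pair in this set isolates such a change, so the expectation rests on the general picture: every measured ester here inhibits growth weakly, and one of the three values sits at the limit (the limit of > 100000 nM in this assay, at which 1 of the 3 values shown sits). The step from compound 1 to compound 4 is therefore expected to be a 1.6-fold higher number from compound 1 to compound 4 (0.20 log units; within the scatter), toward a weaker inhibitor if anything, possibly ending at the limit. Compound 4 is estimated at 100000 nM, with a range from 35000 nM to 300000 nM.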

Compound 4, concentration for 50% growth inhibition: > 100000 nM
Compound 4 was reported as a limit; the forecaster's own chance of this, stated with the estimate: 50%; the middle value lies on the limit itself.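

Among these compounds, on a carbonyl carbon, placing pyridin-3-yl where 2,2-dimethyl-3-(2-methylprop-1-en-1-yl)cyclopropyl stood gives, in this assay, an at least 1.5-fold higher number from compound 1 to compound 4 (0.20 log units; that floor lies within the scatter), and this is the first change at this place that can be read as a step. Compound 4 is reported only as a limit, so the step gives a floor and not a size, and that floor does not separate the two compounds. What the change does show is that this six-membered aromatic ring with 1 hetero atom, on this ester, brings no growth inhibition that can be read as a number, and the limit now holds more of the set: the limit of > 100000 nM in this assay, at which 2 of the 4 values shown sit.

Still open, going by these compounds, is how far compound 4 truly lies from compound 1, and whether the result comes from the ring nitrogen that enters or from the loss of the cyclopropyl group with its double bond. A plain phenyl group on the same carbonyl carbon would separate those two, and an amine on the aromatic ring would show whether this place can yield a readable value at all.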